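Amide substituent swap on a shared sulfonyl-piperidine core

A few compounds are considered here, and "the series" means these few. Any claim that something is new, unique, unknown or untested is made for them only; others in the source may bear on it.

Measured compounds and their values in a functional assay on MIA PaCa-2 cells (Homo sapiens) for inhibition, read by MTT assay, with a stated time of 3 days; a higher number here means a weaker inhibitor, a lower number a stronger inhibitor:
Compound 1, `CCOC(=O)[C@@H]1CCCN(S(=N)(=O)c2ccc(S(=O)(=O)N(CC)CC)cc2)C1`: 4700 nM
Compound 2, `CCN(CC)S(=O)(=O)c1ccc(S(=O)(=O)N2CCC[C@@H](C(=O)N[C@@H]3CCN(C(=O)OC(C)(C)C)C3)C2)cc1`: 500 nM
Compound 3, `CCN(CC)S(=O)(=O)c1ccc(S(=O)(=O)N2CCC[C@@H](C(=O)N3CCN(c4nc(C(F)(F)F)no4)CC3)C2)cc1`: 60 nM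

Compound 2 stands second highest of the three numbers in this assay. Its nearest neighbour is compound 3, whose number is lower by a step beyond the scatter, and the furthest is compound 1, whose number is higher by a step also beyond the scatter.

Compound 4, `CCN(CC)S(=O)(=O)c1ccc(S(=O)(=O)N2CCC[C@@H](C(=O)NC3CN(C(=O)C4CC4)C3)C2)cc1`, has not yet been measured. It differs from compound 2 in one place: 1-(cyclopropylcarbonyl)azetidin-3-yl in place of 1-(tert-butoxycarbonyl)pyrrolidin-3-yl on an amide-type nitrogen. The amide hydrogen on that nitrogen is kept. For the measured compounds named here, no measured pair shows this change, so its effect is unknown from the data at hand. Since compound 2 sits at 500 nM and the change keeps the amide unaltered, the step from compound 2 to compound 4 is expected to be small, estimated at a 1.2-fold higher number from compound 2 to compound 4 (0.08 log units; within the scatter) in this assay, within or close to the scatter. Compound 4 is therefore expected to give about 600 nM, with a range of 150 nM to 2500 nM.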

Compound 4, half-maximal inhibitory concentration: 3100 nM
Compound 4: middle estimate off by 5.2-fold (0.71 log units), on the low side; the measured number lies above the stated range.
By their numbers in this assay, from the lowest: compound 3; then compound 2; then compounds 4 and 1 (each within the scatter of the next).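

Measured in this assay the swap of 1-(tert-butoxycarbonyl)pyrrolidin-3-yl for 1-(cyclopropylcarbonyl)azetidin-3-yl on the amide-type nitrogen gives a 6.2-fold higher number from compound 2 to compound 4 (0.79 log units; beyond the scatter) with the amide hydrogen kept. For the compounds shown here, this is the first comparison here between compounds that differ in one place, and it shows that the number responds clearly to the group on this nitrogen even though the amide itself stays unaltered. Nothing available here explains the shift.

The compounds shown do not separate the ring from the group on its carbonyl, since both change in this one step; 1-(cyclopropylcarbonyl)pyrrolidin-3-yl or 1-(tert-butoxycarbonyl)azetidin-3-yl would pull the two apart. They also leave open how the unacylated pyrrolidin-3-yl amine would read at this position.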